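A Longer Side Chain for Compound 3

The source may report more compounds than this note shows. Statements on the series, on what has been measured and on what is new or still open speak of the compounds shown alone.

In a functional assay on PANC-1 cells (Homo sapiens) for antiproliferative activity, read by WST assay, with a stated time of 96 h (on this read-out higher numbers stand for weaker inhibition and lower numbers for stronger inhibition), compound 1 (`CCC[C@H]1C[C@@H](OC)C/C(C)=C\[C@@H]2C[C@@H](OC(=O)CCCCc3coc(CCCNC(=O)OC)n3)C[C@H](CC(=O)O1)O2`) gives 3200 nM, compound 2 (`CCC[C@H]1C[C@@H](OC)C/C(C)=C\[C@@H]2C[C@@H](OC(=O)/C=C(/C)CCc3coc(/C=C\CNC(=O)OC)n3)C[C@H](CC(=O)O1)O2`) gives 6.4 nM, and compound 3 (`C/C=C\c1nc(CC/C=C\C(=O)O[C@H]2C[C@@H]3CC(=O)O[C@@H](CCC)C[C@@H](OC)C/C(C)=C\[C@H](C2)O3)co1`) gives 440 nM, the middle of the three numbers. Compound 4 (`CCC[C@H]1C[C@@H](OC)C/C(C)=C\[C@@H]2C[C@@H](OC(=O)/C=C\CCc3coc(CCCNC(=O)OC)n3)C[C@H](CC(=O)O1)O2`) carries 3-((methoxycarbonyl)amino)propyl in place of the prop-1-en-1-yl of compound 3 on an aromatic carbon: 3-((methoxycarbonyl)amino)propyl in place of prop-1-en-1-yl on an aromatic carbon. For the measured compounds named here, no measured pair isolates this change, so any forecast is uncertain. The expectation rests on compound 2 at 6.4 nM, which bears a related unsaturated chain, tempered by compound 1 at 3200 nM, which bears the incoming group itself. A moderately lower number is expected in this assay, an estimated 2.9-fold lower number from compound 3 to compound 4 (0.47 log units; beyond the scatter). For compound 4 the estimated value is 150 nM, with an expected range of 30 nM to 700 nM.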

Compound 4, half-maximal inhibitory concentration: 200 nM
Compound 4: middle estimate off by 1.3-fold (0.12 log units), on the low side; low and high end bracket the measured number.
By their numbers in this assay, from the lowest: compound 2; then compound 4; then compound 3; then compound 1.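

In this assay, for the compounds shown here, placing 3-((methoxycarbonyl)amino)propyl instead of prop-1-en-1-yl on this aromatic carbon gives a 2.2-fold lower number from compound 3 to compound 4 (0.34 log units; beyond the scatter) and provides the first direct reading of this change. The step is modest but beyond the scatter, so the position accepts the longer chain with no loss in this read-out. The compounds shown leave open whether the lower number follows from chain length or from the methyl carbamate end, which a plain butyl chain or a terminal amine on this carbon would help separate. No measured evidence bears on why the step arises.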